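Replacing pyridin-4-yl by thiophen-3-yl on the shared core

The compounds below may be only part of what the source reports. "The series", "measured", "known", "first", "only" and "open" are said of these compounds alone.

Within the data shown here, compound 2 `CCOC(=O)c1cnc(-c2ccncc2)nc1NN1C(=O)C=C(C)C1=O` gives 6000 nM in a functional assay on Jurkat cells for inhibition of nuclear factor NF-kappa-B complex (Homo sapiens) (a lower number here means a stronger inhibitor, a higher number a weaker inhibitor), the higher of the two numbers measured so far. Among the measured compounds shown here, its only measured neighbour is compound 1 `CCOC(=O)c1cnc(-c2ccccc2)nc1NN1C(=O)C=C(C)C1=O`, which gives 100 nM; the step of a 60-fold higher number from compound 1 to compound 2 (1.78 log units; beyond the scatter) is the single measured change, and it lies at the same aromatic carbon that is altered here. Compound 3 `CCOC(=O)c1cnc(-c2ccsc2)nc1NN1C(=O)C=C(C)C1=O` differs from compound 2 in one place: thiophen-3-yl in place of pyridin-4-yl on an aromatic carbon. The measured step shows that pyridin-4-yl at this carbon gives a much higher number than phenyl, so removing it is expected to lower the number again; thiophen-3-yl is not phenyl, however, so a full return to the number of compound 1 is uncertain. A large step downward, a 20-fold lower number from compound 2 to compound 3 (1.30 log units; beyond the scatter), is therefore expected. Compound 3 is estimated at 300 nM, with a range from 80 nM to 1500 nM.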

Compound 3, half-maximal inhibitory concentration: 100 nM
Compound 3: middle estimate off by 3.0-fold (0.48 log units), on the high side; the measured number falls inside the stated range.
By their numbers in this assay, from the lowest: compounds 1 and 3 (each within the scatter of the next); then compound 2.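

In this assay, thiophen-3-yl removes the loss seen with pyridin-4-yl at this carbon, with a 60-fold lower number from compound 2 to compound 3 (1.78 log units; beyond the scatter). Against phenyl the same group shows no change at the digits printed from compound 1 to compound 3 (within the scatter), so a five-membered aromatic ring with sulfur serves here as well as the six-membered carbon ring, and among the three groups shown only pyridin-4-yl stands apart. Nothing available explains why pyridin-4-yl differs from the other two groups.

On these data alone, whether pyridin-3-yl or pyridin-2-yl would behave like pyridin-4-yl stays open, as does the outcome with a non-aromatic group such as cyclohexyl or a small chain such as methyl at this carbon. The compounds shown all keep the ethoxycarbonyl group, so what a carboxylic acid or an amide there would do also stays open.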